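Chloro for fluoro on the core: a single-atom swap

The source may hold more compounds than are shown below. What is called first, only, known or untested is meant among the compounds shown, and "the series" means these compounds.

Measured so far:
Compound 1, `CC1CCN(c2c(S(=O)(=O)c3ccccc3)cnc3ccc(Cl)cc23)CC1`: 59%
Compound 2, `CC1CCN(c2c(S(=O)(=O)c3ccc(C#N)cc3)cnc3ccc(F)cc23)CC1`: 75%

Of the compounds shown here, two have been measured in an assay on isolated protein for displacement of a labelled ligand from metabotropic glutamate receptor 5 (Homo sapiens), with a stated time of 60 min, tested at 1 uM; on this read-out higher numbers stand for more inhibition at the one concentration tested (going by the name of the read-out) and lower numbers for less inhibition. Compound 1 `CC1CCN(c2c(S(=O)(=O)c3ccccc3)cnc3ccc(Cl)cc23)CC1` gives 59%. Compound 2 `CC1CCN(c2c(S(=O)(=O)c3ccc(C#N)cc3)cnc3ccc(F)cc23)CC1` gives 75%. Of the two numbers, compound 2 stands highest, and its nearest neighbour, compound 1, sits lower by a gap that lies beyond the usual scatter. Among the compounds with values here, compound 1 and compound 2 differ in more than one place, so no single step between measured compounds is available to guide the next move.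

The next compound, compound 3 `CC1CCN(c2c(S(=O)(=O)c3ccc(C#N)cc3)cnc3ccc(Cl)cc23)CC1`, is reached from compound 2 by one change: chloro in place of fluoro on an aromatic carbon. Within the data shown here, no measured pair shows what a chloro in place of a fluoro at this position does in this assay, so the direction of the step is open. Given the small size of the change, compound 3 is expected to land close to compound 2, with a step of a number 3 percentage points lower from compound 2 to compound 3 (within the scatter) in this assay, that is, none beyond the scatter. Compound 3 is therefore estimated at 72%, with a range from 52% to 88%.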

Compound 3, a percentage reported as inhibition, at one concentration (the size of the read-out at that concentration, not a potency): 31%
Estimate against measurement, compound 3: 41 percentage points above, and the stated range ends above it.
By their numbers in this assay, from the lowest: compound 3; then compound 1; then compound 2.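

In this assay the swap of chloro in place of fluoro on an aromatic carbon of the shared core, one heavy atom for another, brings a number 44 percentage points lower from compound 2 to compound 3 (beyond the scatter) and shows that this position, meta to a fused ring and para to a fused ring, is far from indifferent to which halogen it carries. The other step, cyano in place of hydrogen on an aromatic carbon, brings a number 28 percentage points lower from compound 1 to compound 3 (beyond the scatter) with chloro on the core, so in this setting the cyano goes with less inhibition rather than more, and the high standing of compound 2 cannot be read as a simple gain from cyano. Nothing available on these compounds accounts for either drop.

On these data alone, what cyano in place of hydrogen does with fluoro on the core stays open, and with it the question of whether the two changes act independently or depend on each other. Also open, as far as these compounds go, is how other groups at the same place, such as bromo, methyl or methoxy, would compare with fluoro and chloro in this read-out.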